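Adding a methoxy to the fused ring of compound 2

The compounds below may be only part of what the source reports. "The series", "measured", "known", "first", "only" and "open" are said of these compounds alone.

In a functional assay on HEK293 cells for antagonist activity at proteinase-activated receptor 4 (Homo sapiens), read by FLIPR and calcium flux, with a stated time of 30 min (a lower number here means a stronger inhibitor, a higher number a weaker inhibitor), compound 2 `COc1nn2cc(-c3cc4ccccc4o3)nc2s1` gives 4 nM, the lowest of the three numbers measured. Compound 1 `c1ccc2oc(-c3cn4nc(C5CC5)sc4n3)cc2c1` gives 530 nM, and compound 3 `c1ccc(Sc2nn3cc(-c4cc5ccccc5o4)nc3s2)cc1` gives 1900 nM. The steps between them were all large or modest: a 130-fold lower number from compound 1 to compound 2 (2.12 log units; beyond the scatter), a 3.6-fold higher number from compound 1 to compound 3 (0.55 log units; beyond the scatter) and a 480-fold higher number from compound 2 to compound 3 (2.68 log units; beyond the scatter). Each of these three steps alters the group on the shared core, exchanging cyclopropyl, methoxy and phenylsulfanyl for one another.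

Compound 4 `COc1nn2cc(-c3cc4c(OC)cccc4o3)nc2s1` differs from compound 2 in another way: methoxy in place of hydrogen on an aromatic carbon. Among the compounds with values here, none of the measured steps touches that six-membered aromatic ring of carbon only, so no step on record speaks to it directly; the measured steps show only that this assay is sensitive to changes at the core. With nothing to anchor a direction, the most that can be said is that compound 4 is expected to stay near compound 2 4 nM, with a step of a 1.3-fold higher number from compound 2 to compound 4 (0.10 log units; within the scatter) that is not expected to exceed the scatter. For compound 4 the estimated value in this assay is 5 nM, with a range from 1.5 nM to 20 nM.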

Compound 4, half-maximal inhibitory concentration: 7.6 nM
Estimate against measurement, compound 4: 1.5-fold (0.18 log units) below; the measured number falls inside the stated range.
By their numbers in this assay, from the lowest: compounds 2 and 4 (each within the scatter of the next); then compound 1; then compound 3.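

In this assay, within the data shown here, the step of a 1.9-fold higher number from compound 2 to compound 4 (0.28 log units; within the scatter) gives the first reading on the six-membered aromatic ring of carbon only, and it shows that methoxy in place of hydrogen at this position, ortho to a fused ring and meta to a fused ring, cannot be told apart from hydrogen. The earlier compounds shown here showed only what happens when the group on the shared core is exchanged, where a step such as a 480-fold higher number from compound 2 to compound 3 (2.68 log units; beyond the scatter) lies far beyond the scatter, so this assay's sensitivity at the core does not carry over to this methoxy on the other ring. No measured information bears on why this change makes so little difference, and no explanation can be offered for it.

Whether this holds for other groups at the same position, such as an amine, a carboxylic acid or a longer chain, remains open, since methoxy is the only group shown there. Also open, as far as these compounds go, is whether methoxy on the other carbons of that ring would read the same, or whether this one would do so with cyclopropyl rather than methoxy on the shared core.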